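Chain extension at the saturated ring carbon of compound 2

The source may hold more compounds than are shown below. What is called first, only, known or untested is meant among the compounds shown, and "the series" means these compounds.

Within the data shown here, compound 1 `C1CN=C(NC(C2CC2)C2CC2)C1` and compound 2 `CC1CCC(NC(C2CC2)C2CC2)=N1` are the two compounds measured so far in an assay (Bos taurus) for displacement of a labelled ligand from Nischarin (Homo sapiens); on this read-out lower numbers stand for stronger inhibition and higher numbers for weaker inhibition. Compound 1 gives 513 nM in this assay, and compound 2 gives 1580 nM. Among the measured compounds shown here, the only step available is a 3.1-fold higher number from compound 1 to compound 2 (0.49 log units; beyond the scatter). Compound 2 therefore stands as the higher of the two numbers in this assay, with compound 1 as its nearest neighbour.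

Compound 3 `CCC1CCC(NC(C2CC2)C2CC2)=N1` is not yet measured. It differs from compound 2 by methyl in place of hydrogen on a saturated chain carbon bound to a saturated ring carbon; read one bond further out, the change is methyl to ethyl. For the measured compounds named here, only the step from compound 1 to compound 2 bears on it, and loosely: that step placed the first carbon on the saturated ring carbon, whereas compound 3 adds a carbon on the chain carbon bound to that ring carbon. Since the earlier addition gave a 3.1-fold higher number from compound 1 to compound 2 (0.49 log units; beyond the scatter), a further small rise in this assay is plausible but not assured, and a result within the scatter would not surprise. Compound 3 is therefore expected to give about 2500 nM in this assay, between 1000 nM and 6500 nM. This corresponds to an expected step of a 1.6-fold higher number from compound 2 to compound 3 (0.20 log units; within the scatter).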

Compound 3, inhibition constant: 170 nM
Compound 3: the middle estimate sits 15-fold (1.17 log units) above what was measured; the measured number lies below the stated range.
By their numbers in this assay, from the lowest: compound 3; then compound 1; then compound 2.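

In this assay, among these compounds, the saturated ring carbon does not simply penalise substitution: the step of a 3.1-fold higher number from compound 1 to compound 2 (0.49 log units; beyond the scatter) is turned around by the methyl to ethyl change, which gives a 9.3-fold lower number from compound 2 to compound 3 (0.97 log units; beyond the scatter) and is the largest step so far. Set directly against hydrogen, ethyl gives a 3.0-fold lower number from compound 1 to compound 3 (0.48 log units; beyond the scatter) as well, so with methyl and ethyl moving the number in opposite directions relative to hydrogen, the outcome at this carbon depends on which group is present and not merely on whether one is there. No measurement bearing on this reversal is available, so the data describe it without accounting for it.

With only hydrogen, methyl and ethyl at this position, the compounds shown do not tell whether a longer chain such as propyl or butyl would lower the number further or whether ethyl is already near the best length. They also leave open whether a branched group such as isopropyl, a ring such as cyclopropyl, or a chain ending in a hydroxyl or an amine would be tolerated at the same carbon.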